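Swapping a Short Chain for a Benzyl Group

The compounds below may be only part of what the source reports. "The series", "measured", "known", "first", "only" and "open" are said of these compounds alone.

Measured compounds and their values:
- Compound 1 `CC(C)Nc1sc(C(=O)c2ccc(Br)s2)c(N)c1C#N`: 122 nM
- Compound 2 `CC(C)N(C)c1sc(C(=O)c2ccc(Cl)s2)c(N)c1C#N`: 1420 nM
- Compound 3 `CCNc1sc(C(=O)c2ccc(Cl)s2)c(N)c1C#N`: 222 nM

All three compounds share one core and were tested in an assay for inhibition of Maternal embryonic leucine zipper kinase (Homo sapiens), read by ADP-Glo, with a stated time of 0.5 h; a lower number here means a stronger inhibitor, a higher number a weaker inhibitor. Compound 3 sits second highest of the three numbers. Its nearest neighbour is compound 1, whose value lies within the scatter of compound 3, so no order between them can be claimed. Among the measured compounds shown here, compound 2 stands furthest away, and the step of a 6.4-fold lower number from compound 2 to compound 3 (0.81 log units; beyond the scatter) is the only measured change beyond the scatter; it alters the group on the ring nitrogen.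

Compound 4 `N#Cc1c(NCc2ccccc2)sc(C(=O)c2ccc(Cl)s2)c1N` is not yet measured. It differs from compound 3 by phenyl in place of methyl on a saturated chain carbon bound to a nitrogen on an aromatic ring. For the measured compounds named here, this is again a change at the amine side of the core, the same region touched in the step from compound 2 to compound 3, but no measured pair shows an ethyl replaced by a benzyl, so the direction is uncertain. A change of modest size, roughly within or slightly beyond the scatter, is expected, with a weaker result somewhat more likely, estimated as a 1.4-fold higher number from compound 3 to compound 4 (0.16 log units; within the scatter). For compound 4 the expected value in this assay is 320 nM, with a range from 100 nM to 1100 nM.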

Compound 4, half-maximal inhibitory concentration: > 5000 nM
Compound 4: a limit, no number (the forecaster's own chance of this, stated with the estimate: 3%); at least 15-fold (1.19 log units) between middle value and limit.
By their numbers in this assay, from the lowest: compounds 1 and 3 (each within the scatter of the next); then compound 2. At a limit, above all of these: compound 4.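

Placing a phenyl on the saturated chain carbon bound to the nitrogen does far more than the earlier change at this amine side of the core suggested, giving an at least 22-fold higher number from compound 3 to compound 4 (1.35 log units; beyond the scatter). Benzylamino in place of isopropyl(methyl)amino gives an at least 3.5-fold higher number from compound 2 to compound 4 (0.54 log units; beyond the scatter), so at this position an amino group carrying a single substituent, as in ethylamino, does not keep the number low whatever that substituent is. In this assay compound 4 gives > 5000 nM, which is a limit of the assay and not a number: the limit of > 5000 nM in this assay, at which 1 of the 4 values shown sits.

From the compounds shown here alone, how far the true value of compound 4 lies past that limit stays unknown, so both steps give only a minimum size. Also open, going by these compounds, is whether a propylamino or a cyclohexylmethylamino group would fall closer to compound 3 or to compound 4, which would separate the effect of chain length from that of the aromatic ring.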